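Swapping a Methoxy for Hydrogen on Compound 1

The source may hold more compounds than are shown below. What is called first, only, known or untested is meant among the compounds shown, and "the series" means these compounds.

Within the data shown here, in a functional assay on KB cells (Homo sapiens) for cytotoxicity, read by MTT assay, with a stated time of 72 h (on this read-out lower numbers stand for stronger inhibition and higher numbers for weaker inhibition), compound 1 (`COc1ccc(CCCOC(=O)CCc2ccc(O)cc2)cc1`) gives 820000 nM as the highest number of the three measured so far. Both other compounds give lower numbers: compound 2 (`COc1cc(/C=C/COC(=O)/C=C/c2cc(OC)c(OC)c(OC)c2)cc(OC)c1OC`) gives 206000 nM and compound 3 (`COc1ccc(/C=C/COC(=O)/C=C/c2ccc([N+](=O)[O-])cc2)cc1OC`) gives 165000 nM and neither gap to compound 1 falls within the usual scatter.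

Compound 4 (`O=C(CCc1ccc(O)cc1)OCCCc1ccccc1`) has not been measured yet. It differs from compound 1 by a single change (hydrogen in place of methoxy on an aromatic carbon), namely hydrogen in place of methoxy on an aromatic carbon, para to a large group. Among the measured compounds shown here, no two measured compounds differ in only one place, so the data do not show directly what such a swap does in this assay here. Starting from compound 1 at 820000 nM the expectation is no shift beyond the scatter, with no firm direction. The estimated step of a 1.2-fold lower number from compound 1 to compound 4 (0.07 log units; within the scatter) would therefore stay small. Compound 4 is expected to give 700000 nM with an estimated range from 280000 nM to 1600000 nM when it is tested.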

Compound 4, half-maximal inhibitory concentration: 129000 nM
The estimate for compound 4 lay 5.4-fold (0.73 log units) above the measured number, and the stated range ends above it.
By their numbers in this assay, from the lowest: compounds 4, 3 and 2 (each within the scatter of the next); then compound 1.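

In this assay, among these compounds, this is the first pair of compounds that differ in only one place, so the effect of this swap can now be read directly. Replacing methoxy with hydrogen on the aromatic carbon, para to a large group, gives a 6.4-fold lower number from compound 1 to compound 4 (0.80 log units; beyond the scatter) and thus a clear move beyond the scatter. This position is therefore sensitive to the change, and here compound 4, which carries hydrogen, shows stronger inhibition than compound 1, which carries methoxy.

From the compounds shown here alone, at this position only methoxy and hydrogen can be compared, so it remains open how an amine or a chlorine atom would fare there. No measurement shown bears on why the number falls with this swap.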